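Chloro to nitro exchange in a two-compound cytotoxicity series

This account rests on a few compounds, and the source may have more. Where it says the series, first, only, none or still open, it means among the compounds named here.

Compound 1 `O=C(N/N=C/c1cccc(Cl)c1)c1cnccn1` is the reference point. In an ADME assay on J774 cells (Mus musculus) for cytotoxicity, read by MTT assay, with a stated time of 48 h, tested at 100 ug/mL (a higher number here means a weaker effect of the compound at the concentration tested, a lower number a stronger effect), compound 1 gives 100%, the higher of the two numbers recorded so far. Compound 2 `O=C(N/N=C/c1ccc(F)cc1)c1cnccn1` carries a different group on the aryl ring at a different position; in this assay compound 2 gives 69%, a number lower than that of compound 1 by a margin beyond the usual scatter. Among the measured compounds shown here, no pair that differs in a single place has been measured, so no step size is established.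

Compound 3 `O=C(N/N=C/c1cccc([N+](=O)[O-])c1)c1cnccn1` has not yet been measured. Relative to compound 1 it carries nitro in place of chloro on an aromatic carbon. Since substituent changes on the ring have moved the read-out between compound 1 and compound 2, a modest downward step is expected, likely within or just past the scatter. The expected step is a number 10 percentage points lower from compound 1 to compound 3 (within the scatter). For compound 3 the estimated read-out in this assay is 90%, with a range from 65% to 100%.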

Compound 3, a percentage reported as activity, at one concentration (the size of the read-out at that concentration, not a potency): 85%
The estimate for compound 3 lay 5 percentage points above the measured number; measured number inside the range.
By their numbers in this assay, from the lowest: compound 2; then compound 3; then compound 1.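

In this assay, among the compounds shown here, nitro in place of chloro on an aromatic carbon gives the first single-place step: a number 15 percentage points lower from compound 1 to compound 3 (beyond the scatter). With the rest of compound 1 held constant, this change alone moves the read-out beyond the usual scatter, towards a stronger effect at the concentration tested, so the group at this position, meta to a large group, matters to the read-out. Nothing measured here accounts for the step.

On these data alone, it remains open whether other groups at this position, such as an amine, a carboxylic acid or a methoxy group, would continue this downward shift or reverse it. Compound 2 differs from compound 1 in both its group and its place on the ring, so the contribution of each change remains unresolved.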